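This account rests on a few compounds, and the source may have more. Where it says the series, first, only, none or still open, it means among the compounds named here.

Within the data shown here, in a functional assay on HEK293 cells for antagonist activity at Voltage-dependent L-type calcium channel subunit alpha-1D (Rattus norvegicus), read by FLIPR (a lower number here means a stronger inhibitor, a higher number a weaker inhibitor), compound 3 `COC(=O)C1=C(C)NC(C)=C(C(=O)OCC2CC2)C1c1cccc([N+](=O)[O-])c1` gives 21 nM, the lowest number among the three compounds measured so far. Compound 2 `CCOC(=O)C1=C(C)NC(/C=C/C#N)=C(C(=O)OCC)C1c1cccc([N+](=O)[O-])c1` gives 45 nM, and compound 1 `CCOC(=O)C1=C(C)NC(C(OCC)OCC)=C(C(=O)OCC)C1c1cccc([N+](=O)[O-])c1` gives 615 nM. Among the measured compounds shown here, the one measured step between close neighbours, a 14-fold lower number from compound 1 to compound 2 (1.14 log units; beyond the scatter), concerns a group on a double-bonded ring carbon and leaves both ester groups untouched.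

Compound 4 `COC(=O)C1=C(C)NC(C)=C(C(=O)OCc2ccccc2)C1c1cccc([N+](=O)[O-])c1` differs from compound 3 in one ester only: phenyl in place of cyclopropyl on a saturated chain carbon bound to an oxygen next to a carbonyl group. For the measured compounds named here, no measured pair changes this part of the shared core, so the size of this step cannot be read off any earlier comparison; the numbers of compound 1 and compound 2 show only what a change elsewhere on the core did. With nothing pointing in either direction, the expected step is a 1.2-fold lower number from compound 3 to compound 4 (0.07 log units; within the scatter), small and with wide room on both sides. Compound 4 is estimated at 18 nM in this assay, with a range from 5 nM to 70 nM.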

Compound 4, half-maximal inhibitory concentration: 15 nM
Compound 4: middle estimate off by 1.2-fold (0.08 log units), on the high side; low and high end bracket the measured number.
By their numbers in this assay, from the lowest: compounds 4 and 3 (each within the scatter of the next); then compound 2; then compound 1.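

In this assay, the only step shown at this ester position is a 1.4-fold lower number from compound 3 to compound 4 (0.15 log units; within the scatter) and it is small enough to count as no real difference. A three-membered non-aromatic ring and a six-membered aromatic ring, each on the saturated chain carbon bound to an oxygen next to a carbonyl group, therefore cannot be told apart by this read-out. This suggests that, for this one pair, the change in ring size and type leaves the inhibitor's number unmoved, and no measurement at hand offers an explanation for that.

On these data alone, whether this tolerance extends to other groups at the same place remains open, such as a longer chain, an amine or a carboxylic acid. A single pair also cannot show whether a phenyl ring carrying a further group, such as a methoxy group, would behave the same way.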